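An aromatic ring exchanged on compound 1

The source may hold more compounds than are shown below. What is called first, only, known or untested is meant among the compounds shown, and "the series" means these compounds.

Three compounds have numbers in a physicochemical assay for lipophilicity, read by HPLC, at pH 7.5; on this read-out higher numbers stand for higher lipophilicity and lower numbers for lower lipophilicity. Compound 1 `CC[C@@H](Nc1c(C#N)c(-c2ccc(-c3ccncc3C)cc2)nc2cnccc12)C(N)=O` gives 2, compound 2 `CCOc1ccccc1-c1ccc(-c2nc3cnccc3c(C[C@H](C)C(=O)O)c2C#N)cc1` gives 2.2, and compound 3 `CCOc1ccccc1-c1ccc(-c2nc3cnccc3c(N[C@H](CC)C(=O)NS(=O)(=O)C3CC3)c2C#N)cc1` gives 2.3. Compound 1 thus stands within the scatter of both others, and the three cannot be ranked. Compound 4 `CC[C@@H](Nc1c(C#N)c(-c2ccc(-c3cccc(CO)c3)cc2)nc2cnccc12)C(N)=O` has not yet been measured. It keeps the rest of compound 1 and carries 3-(hydroxymethyl)phenyl in place of 3-methylpyridin-4-yl on an aromatic carbon. The exchange sits on an aromatic carbon of a six-membered aromatic ring of carbon only, para to a large group. For the measured compounds named here, no measured pair differs in one place, so the data show no direct precedent for this change. Going by the values given here, the only guide is how closely the measured numbers lie, with compound 1 at 2 and compound 3 at 2.3. The expected step of a number 0.10 log units higher from compound 1 to compound 4 (within the scatter) is small, and no move beyond the scatter is expected in either direction. In this assay the estimate for compound 4 is 2.1, with an expected range from 1.7 to 2.5.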

Compound 4, distribution coefficient: 2
Compound 4: the middle estimate sits 0.10 log units above what was measured; the measured number falls inside the stated range.
By their numbers in this assay, from the lowest: compounds 1, 4, 2 and 3 (each within the scatter of the next).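

For the compounds shown here, replacing 3-methylpyridin-4-yl with 3-(hydroxymethyl)phenyl gives the only step read at a single place, and in this assay it shows no change at the digits printed from compound 1 to compound 4 (within the scatter). Going by these compounds alone, on this aromatic carbon, a ring of carbon only bearing a hydroxymethyl group can therefore stand in for a ring with one hetero atom without a move beyond the scatter, which the earlier compounds, differing in more than one place, could not show. Nothing at hand explains this result.

As far as these compounds go, it remains open whether the same would hold with an amine or a carboxylic acid on the ring in place of hydroxymethyl, or with a longer chain such as hydroxyethyl. A single step also leaves open how a ring with a second nitrogen would read at this position.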